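Extending the chain between triazole and amide

The source may report more compounds than this note shows. Statements on the series, on what has been measured and on what is new or still open speak of the compounds shown alone.

Compound 1 `Cc1ccc(NC(=O)CCCCc2cn(Cc3ccc4oc(-c5ccc(Cl)cc5)cc(=O)c4c3)nn2)cc1` gives 32900 nM in an assay on isolated protein for inhibition of Amine oxidase [flavin-containing] B (Homo sapiens), read by fluorescence and spectrophotometry; a lower number here means a stronger inhibitor, a higher number a weaker inhibitor. Compound 2 `O=C(NCc1cn(Cc2ccc3oc(-c4ccccc4)cc(=O)c3c2)nn1)c1ccccc1` gives 15600 nM.

Of the two numbers, compound 2 has the lower one, and its gap to compound 1 lies beyond the usual scatter. Compound 3 `O=C(CCCCc1cn(Cc2ccc3oc(-c4ccccc4)cc(=O)c3c2)nn1)Nc1ccccc1` differs from compound 2 by 3-(phenylcarbamoyl)propyl in place of benzamido on a saturated chain carbon bound to an aromatic carbon. Within the data shown here, no measured pair isolates this change, so the step is expected to be small, a modest weakening at most, with a 1.5-fold higher number from compound 2 to compound 3 (0.19 log units; within the scatter) as the estimate. Compound 3 is therefore expected at 24000 nM, within 8000 nM to 75000 nM.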

Compound 3, half-maximal inhibitory concentration: 15600 nM
Compound 3: the middle estimate sits 1.5-fold (0.19 log units) above what was measured; low and high end bracket the measured number.
By their numbers in this assay, from the lowest: compounds 2 and 3 (each within the scatter of the next); then compound 1.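

Replacing benzamido with 3-(phenylcarbamoyl)propyl on a saturated chain carbon bound to an aromatic carbon gives no change at the digits printed from compound 2 to compound 3 (within the scatter) in this assay and so shows that this place accepts the larger group, with 12 heavy atoms instead of 9, without a measurable loss. No measurement shown here explains this result. This one change alters both the chain and the way the amide is attached, and the compounds shown do not separate the two. From the compounds shown here alone, whether an amine or a carboxylic acid could stand in place of the amide also remains open.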